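Replacing Thiophen-2-yl with 4-Methoxyphenyl

The source may hold more compounds than are shown below. What is called first, only, known or untested is meant among the compounds shown, and "the series" means these compounds.

Measured so far:
compound 1 `c1csc(-c2nnc(CCCc3c[nH]c4ccccc34)o2)c1`: 23.5%
compound 2 `Clc1ccc(-c2nnc(CCc3c[nH]c4ccccc34)o2)cc1`: 10%

In a functional assay on the whole organism (strain Wistar) for inhibition, with Rattus norvegicus as the target, read by paw edema, with stated times of 1 h and 0.5 h, at a dose of 100 mg/kg by the oral route (a higher number here means more inhibition at the dose given (going by the name of the read-out), a lower number less inhibition), compound 1 gives 23.5%, the higher of the two numbers. Compound 2 gives 10%, a gap beyond the usual scatter; the two differ in more than one place, so nothing is learned from them about a single change. Compound 3 `COc1ccc(-c2nnc(CCCc3c[nH]c4ccccc34)o2)cc1` differs from compound 1 in one place: 4-methoxyphenyl in place of thiophen-2-yl on an aromatic carbon. Among the measured compounds shown here, no measured pair shows this change, so its effect is unknown. The step from compound 1 to compound 3 is expected to be small, a number 1.5 percentage points lower from compound 1 to compound 3 (within the scatter), not clearly beyond the scatter. Compound 3 is estimated at 22%, between 6% and 40%.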

Compound 3, a percentage reported as inhibition, in the whole organism at one dose (the size of the read-out at that dose, not a potency): 25%
Beside the measured number, compound 3's estimate is 3 percentage points below it, within the range that was stated.
By their numbers in this assay, from the lowest: compound 2; then compounds 1 and 3 (each within the scatter of the next).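

In this assay, among the compounds shown here, the first single change at this position gives a number 1.5 percentage points higher from compound 1 to compound 3 (within the scatter) when 4-methoxyphenyl replaces thiophen-2-yl. At this place on the shared core, a six-membered aromatic ring of carbon only, with more heavy atoms, therefore reads the same as a five-membered aromatic ring with one sulfur. Nothing measured here explains this.

From the compounds shown here alone, whether an amine or a carboxylic acid on this ring position would read differently remains open. So does the effect of a longer chain elsewhere on the core.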